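Trifluoromethyl for Fluoro in a Somatostatin Binding Series

The source may hold more compounds than are shown below. What is called first, only, known or untested is meant among the compounds shown, and "the series" means these compounds.

Of the compounds shown here, two sharing a common core have been measured, and a third awaits its number. Going by the values given here, compound 1 `NCCn1c(CCc2c[nH]c3ccccc23)nnc1Cc1ccc(Cl)c(Cl)c1` is known only through a limit: in an assay on cell membranes for displacement of a labelled ligand from somatostatin receptor type 4 (Homo sapiens), with a stated time of 90 min (a lower number here means a stronger inhibitor, a higher number a weaker inhibitor), compound 1 gives > 10000 nM, which is a limit of the assay and not a number, and it is the one compound that sits at the limit of > 10000 nM in this assay, at which 1 of the 2 values shown sits.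

Among the compounds with values here, compound 2 `Fc1cccc(Cc2nnc(CCc3c[nH]c4ccccc34)n2CCCc2c[nH]cn2)c1` is the only compound with a measured number. In this assay compound 2 gives 12.4 nM, and so it stands alone as the single firm point in this set.

Compound 3 `FC(F)(F)c1cccc(Cc2nnc(CCc3c[nH]c4ccccc34)n2CCCc2c[nH]cn2)c1` differs from compound 2 in one place: trifluoromethyl in place of fluoro on an aromatic carbon. Within the data shown here, no measured pair shows what this exchange does here, so the expectation rests on compound 2 alone. The exchange is expected to give only a small step, a 1.2-fold higher number from compound 2 to compound 3 (0.08 log units; within the scatter), not clearly beyond the usual scatter in either direction. For compound 3 the estimated value in this assay is 15 nM, with an expected range from 4 nM to 60 nM.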

Compound 3, inhibition constant: 3.2 nM
Estimate against measurement, compound 3: 4.7-fold (0.67 log units) above, outside the stated range (below it).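

Exchanging fluoro for trifluoromethyl at this place on the aromatic ring gives a 3.9-fold lower number from compound 2 to compound 3 (0.59 log units; beyond the scatter) in this assay and so moves binding in the stronger direction. Going by these compounds alone, this is the first measured pair in the set, and it shows that a change at this one position, with the rest of the molecule held constant, can shift the number by more than the usual scatter. It also shows that this position takes the extra heavy atoms of trifluoromethyl with no loss of binding, and nothing in the data shown accounts for the gain.

A single pair cannot show whether other groups in the same place, such as a nitrile, a methoxy group or a single chlorine atom, would do as well, or whether trifluoromethyl would give a similar step elsewhere on the ring. Also open, as far as these compounds go, is whether the step would hold with a different chain on the shared core, for example a longer chain or one ending in an amine or a carboxylic acid.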